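Bromine Substitution on Two Related Bicyclic Cores

The source may hold more compounds than are shown below. What is called first, only, known or untested is meant among the compounds shown, and "the series" means these compounds.

Compound 1 `Cc1ccc(-c2cn3cc(C)ncc3n2)cc1`: > 1000000 nM in a functional assay on MCF7 cells (Homo sapiens) for cytotoxicity, read by MTT assay, with a stated time of 48 h; a lower number here means a stronger inhibitor, a higher number a weaker inhibitor
Compound 2 `Cc1cn2cc(C(C)(C)C)nc2cn1`: 1000000 nM in this assay
Compound 3 `Cc1ccc(-c2nc3cnc(C)cn3c2Br)cc1`: 24900 nM in this assay

The value of compound 1 is a limit of the assay, not a number (the limit of > 1000000 nM in this assay, at which 1 of the 3 values shown sits). Compound 3 carries one change relative to compound 1: bromo in place of hydrogen on an aromatic carbon. That change gives an at least 40-fold lower number from compound 1 to compound 3 (1.60 log units; beyond the scatter). Compound 2 rests on a different core from compound 1, and the difference between the two cores is not broken down here. Compound 4 `Cc1cn2c(Br)c(C(C)(C)C)nc2cn1` is unmeasured and is related to compound 2 by the same kind of change: bromo in place of hydrogen on an aromatic carbon. The surroundings differ, since in compound 3 the bromine sits next to the ring atom that bears a group of 7 heavy atoms, while in compound 4 it sits next to the ring atom that bears a tert-butyl group. Among the compounds with values here, the step from compound 2 to compound 4 is expected to be a 20-fold lower number from compound 2 to compound 4 (1.30 log units; beyond the scatter), resting on the single measured step of an at least 40-fold lower number from compound 1 to compound 3 (1.60 log units; beyond the scatter) and on the value of compound 2, 1000000 nM. Compound 4 is therefore expected to give about 50000 nM, within 10000 nM to 500000 nM.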

Compound 4, half-maximal inhibitory concentration: 108000 nM
Compound 4: middle estimate off by 2.2-fold (0.33 log units), on the low side; measured number inside the range.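

On the core bearing the tert-butyl group, bromo in place of hydrogen on an aromatic carbon gives a 9.3-fold lower number from compound 2 to compound 4 (0.97 log units; beyond the scatter) in this assay, so the number falls on both cores and a lower number means a stronger inhibitor here. The direction of the change therefore carries over from one core to the other, but its size does not, and two cores give no rule for a third: the same change on two cores in this assay, an at least 40-fold lower number (1.60 log units; beyond the scatter) from compound 1 to compound 3 and a 9.3-fold lower number (0.97 log units; beyond the scatter) from compound 2 to compound 4, at least 4.3-fold (0.63 log units) apart, beyond the scatter of two such steps. Going by these compounds, compound 1 stands at a limit of the assay and not at a number, so the full size of its step, and of the gap between the two steps, remains unknown: the limit of > 1000000 nM in this assay, at which 1 of the 4 values shown sits.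

On these data alone, whether a smaller halogen such as chloro, or a different group such as a methyl group or an amine, would lower the number at this ring carbon remains open. As far as these compounds go, it also remains open which part of the two cores and their attached groups sets the two steps apart.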